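Chlorine for Methyl on the Aryl Ring at the Saturated Carbon

The source may hold more compounds than are shown below. What is called first, only, known or untested is meant among the compounds shown, and "the series" means these compounds.

Compound 1 `COc1cc(N2C(N)=C(C#N)C(c3c(O)ccc4ccccc34)C3=C2CC(C)(C)CC3=O)cc(OC)c1OC`: 10%
Compound 2 `COc1cc(N2C(N)=C(C#N)C(c3ccc(C)cc3)C3=C2CC(C)(C)CC3=O)cc(OC)c1OC`: 50%

In a functional assay on Ehrlich cells (Mus musculus) for cytotoxicity, tested at 25 ug/mL (a lower number here means a weaker effect, a higher number a stronger effect of the compound at the concentration tested), compound 1 gives 10% and compound 2 gives 50%. Compound 2 thus holds the higher of the two measured numbers, with compound 1 standing a number 40 percentage points higher from compound 1 to compound 2 (beyond the scatter) apart. Compound 3 `COc1cc(N2C(N)=C(C#N)C(c3ccccc3Cl)C3=C2CC(C)(C)CC3=O)cc(OC)c1OC` differs from compound 2 by 2-chlorophenyl in place of 4-methylphenyl on a saturated ring carbon. For the measured compounds named here, the only measured step touching this saturated ring carbon is a number 40 percentage points higher from compound 1 to compound 2 (beyond the scatter), which shows the position matters, yet it compares unlike groups and gives no direction for the new one. A moderate fall, a number 15 percentage points lower from compound 2 to compound 3 (beyond the scatter), is therefore expected with wide uncertainty. Compound 3 is estimated at 35%, within 10% to 60%.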

Compound 3, a percentage reported as activity, at one concentration (the size of the read-out at that concentration, not a potency): 15%
Compound 3: the middle estimate sits 20 percentage points above what was measured; the range from low to high includes it.
By their numbers in this assay, from the lowest: compounds 1 and 3 (each within the scatter of the next); then compound 2.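

Replacing 4-methylphenyl by 2-chlorophenyl in this assay gives a number 35 percentage points lower from compound 2 to compound 3 (beyond the scatter) and so the high number of compound 2 does not hold for every phenyl group at this saturated ring carbon. The step of a number 5 percentage points higher from compound 1 to compound 3 (within the scatter) leaves 2-chlorophenyl and 2-hydroxynaphthalen-1-yl indistinguishable here, and among these three groups only 4-methylphenyl stands apart. Nothing available here explains the difference between these groups. This change alters both the substituent and where it sits on the phenyl ring, so the fall cannot be assigned to either alone. A 4-chlorophenyl or 2-methylphenyl group would separate the two.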